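Swapping the sulfonyl aryl group in a hydroxamate series

The source may report more compounds than this note shows. Statements on the series, on what has been measured and on what is new or still open speak of the compounds shown alone.

Of the compounds shown here, three have been tested in an assay on isolated protein for inhibition of bone morphogenetic protein 1 (Homo sapiens); on this read-out higher numbers stand for weaker inhibition and lower numbers for stronger inhibition. Compound 1 `CC(=O)N[C@@H](CCCN=C(N)N)C(=O)N[C@@H](C)C(=O)NO` gives only a limit of the assay, > 800000 nM, so no number is available for it; that limit is recorded as the limit of > 800000 nM in this assay, at which 1 of the 3 values shown sits. Compound 2 `CC[C@H](C)[C@H](NS(=O)(=O)c1cc(Br)c(Br)s1)C(=O)N[C@@H](CNC(=O)OCc1ccccc1)C(=O)NO` gives 52 nM in this assay. Compound 3 `CC[C@@H](C)[C@@H](NC(=O)OCc1ccccc1)C(=O)NCC(NCc1ccccc1)C(=O)NO` gives 94 nM in this assay. Among the two real numbers the one for compound 2 is the smaller, yet compound 3 sits within the usual scatter of it, so the two cannot be told apart, and no step between measured compounds can be drawn.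

Compound 4 `CC[C@H](C)[C@H](NS(=O)(=O)c1cc(Cl)ccc1Cl)C(=O)N[C@@H](CNC(=O)OCc1ccccc1)C(=O)NO` has not yet been measured in this assay. It differs from compound 2 at a single point: 2,5-dichlorophenyl in place of 4,5-dibromothiophen-2-yl on a sulfonyl sulfur. The rest of the molecule, including the hydroxamate and the benzyl carbamate, is unchanged.

Within the data shown here, no pair among the measured compounds reports on such a change, so the expectation rests on the closeness of compound 2 and compound 3 alone. Compound 4 is expected to lie near compound 2, with the step of a 1.5-fold higher number from compound 2 to compound 4 (0.19 log units; within the scatter) estimated to stay within the scatter or at most be a modest weakening. Compound 4 is therefore estimated at 80 nM in this assay, with a range from 25 nM to 300 nM.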

Compound 4, half-maximal inhibitory concentration: 65 nM
Compound 4: the middle estimate sits 1.2-fold (0.09 log units) above what was measured, within the range that was stated.
By their numbers in this assay, from the lowest: compounds 2, 4 and 3 (each within the scatter of the next). At a limit, above all of these: compound 1.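

In this assay, among these compounds, the exchange on the sulfonyl sulfur comes to a 1.3-fold higher number from compound 2 to compound 4 (0.10 log units; within the scatter), so this pair gives the first direct reading at this position. With the hydroxamate and the benzyl carbamate held constant, a five-membered aromatic ring with a hetero atom and two bromines, and a six-membered aromatic ring of carbon only with two chlorines, cannot be told apart on this read-out, even though the two groups differ in ring size, halogen and hydrogen-bond acceptor count. The data shown give no reason for this closeness, and nothing measured bears on the cause.

As this is a single pair, it leaves open how far the position stays insensitive: a carboxylic acid or an amine on the aromatic ring, a plain phenyl without halogens, or an open butyl chain in place of the ring could each read quite differently. It also leaves open whether the same exchange would read alike if a free amine stood in place of the benzyl carbamate.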